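Swapping the Basic Ring on the Shared Core

The compounds below may be only part of what the source reports. "The series", "measured", "known", "first", "only" and "open" are said of these compounds alone.

Measured compounds:
compound 1, `CC(C)CN1CCN(c2ccc3c(c2)oc(=O)n3C(=O)NCCCCc2ccccc2)CC1`: 127 nM
compound 2, `CCCCCNC(=O)n1c(=O)oc2cc(-c3ccc(F)cc3)ccc21`: 60 nM
compound 3, `CN1CCC(c2cc3oc(=O)n(C(=O)NCCCCc4ccccc4)c3cc2F)CC1`: 24 nM

In an assay on HEK293 cells for inhibition of acid ceramidase (Homo sapiens), read by fluorescence, with stated times of 10 min and 3 h (on this read-out higher numbers stand for weaker inhibition and lower numbers for stronger inhibition), compound 1 gives the highest of the three numbers. Compound 2 sits beyond the scatter below it, and compound 3 lies further still, also beyond the scatter. Compound 1 is therefore the weakest inhibitor among those measured in this assay.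

Compound 4, `CC(C)CN1CCC(c2ccc3c(c2)oc(=O)n3C(=O)NCCCCc2ccccc2)CC1`, has not yet been measured. It differs from compound 1 in one place: 1-isobutylpiperidin-4-yl in place of 4-isobutylpiperazin-1-yl on an aromatic carbon. For the measured compounds named here, no pair of measured compounds differs in that single place, so the size of this step cannot be read off directly. Compound 3, which carries a 1-methylpiperidin-4-yl group among other changes, gives 24 nM, but it differs from compound 1 in more than one place, so its value only hints at direction.

Compound 4 is expected to give 70 nM in this assay, with a range from 25 nM to 200 nM. The estimated step of a 1.8-fold lower number from compound 1 to compound 4 (0.26 log units; within the scatter) is expected to be a modest improvement, close to the edge of the scatter.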

Compound 4, half-maximal inhibitory concentration: 120 nM
For compound 4 the middle estimate is 1.7-fold (0.23 log units) below the measured one, within the range that was stated.
By their numbers in this assay, from the lowest: compound 3; then compounds 2, 4 and 1 (each within the scatter of the next, the first and the last beyond it).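

In this assay, replacing 4-isobutylpiperazin-1-yl with 1-isobutylpiperidin-4-yl on this aromatic carbon gives a 1.1-fold lower number from compound 1 to compound 4 (0.02 log units; within the scatter). For the compounds shown here, this is the first comparison at this position in which only one place changes, and it shows that the number holds when the ring keeps its isobutyl group and its six-membered size but has one hetero atom rather than two. No supporting measurement accounts for this lack of change.

The compounds shown leave open whether the number at this position would hold with a morpholine ring or an open-chain amine such as dimethylamino in place of these rings. They also leave open whether a longer chain such as n-hexyl in place of the isobutyl group would move the number on either ring.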